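A few compounds are considered here, and "the series" means these few. Any claim that something is new, unique, unknown or untested is made for them only; others in the source may bear on it.

Measured so far:
compound 1 `O=C(O)Cc1sc(C(c2ccc(F)cc2)c2ccc(F)cc2)nc1-c1ccccc1` — 240 nM
compound 2 `NS(=O)(=O)c1cccc(-c2nc(C(c3ccc(F)cc3)c3ccc(F)cc3)sc2CC(=O)O)c1` — 710 nM

Among the compounds with values here, in an in vitro functional assay on HEK285-7 cells for antagonist activity at prostaglandin D2 receptor 2 (Homo sapiens), read by BRET and beta-arrestin recruitment (on this read-out higher numbers stand for weaker inhibition and lower numbers for stronger inhibition), compound 2 has the higher of the two numbers, and the one measured step, a 3.0-fold higher number from compound 1 to compound 2 (0.47 log units; beyond the scatter), is modest. Compound 3 `CS(=O)(=O)Nc1cccc(-c2nc(C(c3ccc(F)cc3)c3ccc(F)cc3)sc2CC(=O)O)c1` differs from compound 2 by methanesulfonamido in place of sulfamoyl on an aromatic carbon. Within the data shown here, no measured step swaps one such group for another; the step to compound 2 only shows that attaching a group of this kind at this place cost a little. Both groups carry one hydrogen-bond donor and two acceptors, so no shift beyond the scatter is expected, a 1.1-fold lower number from compound 2 to compound 3 (0.04 log units; within the scatter). Compound 3 is therefore estimated at 650 nM, within 220 nM to 1900 nM.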

Compound 3, half-maximal inhibitory concentration: 370 nM
The estimate for compound 3 lay 1.8-fold (0.24 log units) above the measured number; the measured number falls inside the stated range.
By their numbers in this assay, from the lowest: compounds 1, 3 and 2 (each within the scatter of the next, the first and the last beyond it).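

In this assay, methanesulfonamido in place of sulfamoyl at this place on the aromatic ring gives a shift within the scatter (a 1.9-fold lower number from compound 2 to compound 3 (0.28 log units; within the scatter)), so the two groups cannot be told apart here. Methanesulfonamido also stays within the scatter of the compound that carries only hydrogen at this place (a 1.5-fold higher number from compound 1 to compound 3 (0.19 log units; within the scatter)), so a group here need not bring a measurable loss. Nothing available explains this result.

An amine or a carboxylic acid at this place remains an open case. So does a longer chain in place of the methyl of methanesulfonamido.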